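The source may hold more compounds than are shown below. What is called first, only, known or untested is meant among the compounds shown, and "the series" means these compounds.

Measured in a functional assay on the whole organism for inhibition, with Rattus norvegicus as the target, at a dose of 30 mg/kg; on this read-out lower numbers stand for less inhibition and higher numbers for more inhibition at the one dose given (going by the name of the read-out):

compound 1, `Cc1ccc(-c2nc3cccnc3o2)cc1`: 0%
compound 2, `Fc1ccc(-c2nc3cccnc3o2)cc1`: 27%
compound 3, `COc1cccc(-c2nc3cccnc3o2)c1`: 0%

Within the data shown here, all three share one core and differ only in the single group carried on the outer benzene ring. Among the measured compounds shown here, compound 2 stands highest of the three in this assay, and its separation from compound 1 and from compound 3 is in each case beyond the scatter, so it is the one compound here that shows clear inhibition at this dose. For the measured compounds named here, the only measured step that changes just one place is the one from methyl to fluoro on that ring, a number 27 percentage points higher from compound 1 to compound 2 (beyond the scatter), a modest gain. Compound 3 with its methoxy group and compound 1 with its methyl group both give no inhibition.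

Compound 4, `O=[N+]([O-])c1ccc(-c2nc3cccnc3o2)cc1`, has not yet been measured. It differs from compound 2 as follows: nitro in place of fluoro on an aromatic carbon. Going by the values given here, this is the same kind of change as the measured step, a swap of the one group on that ring, but the nitro group is new to this set, so no measured step tells its direction. The expectation for compound 4 is therefore a step of a number 3 percentage points higher from compound 2 to compound 4 (within the scatter), that is no change beyond the scatter. Compound 4 is estimated at 30%, within 5% to 60%.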

Compound 4, a percentage reported as inhibition, in the whole organism at one dose (the size of the read-out at that dose, not a potency): 5%
The estimate for compound 4 lay 25 percentage points above the measured number; low and high end bracket the measured number.
By their numbers in this assay, from the lowest: compounds 1, 3 and 4 (each within the scatter of the next); then compound 2.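

In this assay, putting nitro in place of fluoro on this aromatic carbon, para to a group of 9 heavy atoms, gives a step of a number 22 percentage points lower from compound 2 to compound 4 (beyond the scatter) and shows that the inhibition seen with fluoro does not carry over to every group placed here. Against methyl at the same carbon, nitro gives a step of a number 5 percentage points higher from compound 1 to compound 4 (within the scatter), which leaves compound 1 and compound 4 indistinguishable in this test and compound 2 as the only one of the three with clear inhibition. No measurement is available that would explain why fluoro stands apart from nitro and methyl here.

The compounds shown leave open whether chloro, an amine or a carboxylic acid on this carbon would keep, raise or lose the inhibition seen with fluoro. They also leave open whether fluoro would keep that inhibition on another carbon of the same ring, and how compound 2 would behave at other doses, as the read-out covers a single dose.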